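Swapping amino for methoxy on the aryl ketone

This account rests on a few compounds, and the source may have more. Where it says the series, first, only, none or still open, it means among the compounds named here.

Of the compounds shown here, three sharing one core have been measured in a functional assay on UO-31 cells (Homo sapiens) for cytotoxicity, read by sulforhodamine B assay, with a stated time of 48 h, tested at 1 uM; a lower number here means a stronger effect, a higher number a weaker effect of the compound at the concentration tested. Compound 1 `COc1cc(-c2cc(/C=C/C(=O)c3ccc(N)cc3)[nH]n2)cc(OC)c1OC` gives 71%. Compound 2 `COc1ccc(-c2cc(/C=C/C(=O)c3ccc(OC)c(OC)c3)[nH]n2)cc1` gives 61%, and compound 3 `COc1ccc(-c2cc(/C=C/C(=O)c3ccc(N)cc3)[nH]n2)cc1OC` gives 86%. On these numbers compound 1 stands second highest of the three: compound 2 lies within the scatter of it, while compound 3 lies beyond the scatter, the step of a number 15 percentage points higher from compound 1 to compound 3 (beyond the scatter) being modest.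

The next compound, compound 4 `COc1ccc(C(=O)/C=C/c2cc(-c3cc(OC)c(OC)c(OC)c3)n[nH]2)cc1`, differs from compound 1 by methoxy in place of amino on an aromatic carbon. Within the data shown here, the only measured step, from compound 1 to compound 3, concerns a different ring of the core, not the aromatic carbon where this change sits, so no measured step bears directly on it. Among the measured compounds shown here, compound 2 carries methoxy groups on the corresponding ring and compound 3 carries the amino group, but these two differ in more than one place and yield no clean step. The account therefore expects no step beyond the scatter, a number 3 percentage points lower from compound 1 to compound 4 (within the scatter). In this assay compound 4 is estimated at 68%, within a range from 50% to 86%.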

Compound 4, a percentage reported as activity, at one concentration (the size of the read-out at that concentration, not a potency): 77%
Estimate against measurement, compound 4: 9 percentage points below, within the range that was stated.
By their numbers in this assay, from the lowest: compounds 2, 1, 4 and 3 (each within the scatter of the next, the first and the last beyond it).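

In this assay, the change from 4-aminophenyl to 4-methoxyphenyl gives a number 6 percentage points higher from compound 1 to compound 4 (within the scatter), the first step measured at this position on the aryl ketone. On the core of compound 1, this position therefore accepts methoxy for amino without a shift beyond the scatter, even though methoxy enters with 0 hydrogen-bond donors where amino had 1. No available evidence accounts for this result.

The compounds shown leave open whether the same exchange would behave alike on the core of compound 3, where the other ring differs. They also leave open how a hydroxyl group, a dimethylamino group or a carboxylic acid would read at this position, and whether a longer alkoxy chain would differ from methoxy.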